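The source may report more compounds than this note shows. Statements on the series, on what has been measured and on what is new or still open speak of the compounds shown alone.

Working notes on the series. Compound 3 `COc1ccc(Sc2nc3cc(N)cc(N)c3nc2-c2ccccc2)cc1` in a functional assay on SF-268 cells (Homo sapiens) for inhibition, read by sulforhodamine B assay, with a stated time of 48 h (a higher number here means that more compound is tolerated, a lower number that less compound is tolerated), gives < 100000 nM, and this is a limit of the assay rather than a number. Compound 1 `Nc1cc(N)c2nc(-c3ccccc3)c(Oc3ccc(Cl)c(Cl)c3)nc2c1` gives < 100000 nM, likewise a limit. Going by the values given here, compound 2 `Nc1cc(N)c2nc(-c3ccccc3)c(NCc3ccc(F)cc3)nc2c1` gives 40700 nM, the only full number among the three. The measured steps between them are a step that the two limits leave unreadable from compound 1 to compound 3, a step that the limit leaves unreadable from compound 2 to compound 3 and a step that the limit leaves unreadable from compound 1 to compound 2; their sizes cannot be read, because the limit of < 100000 nM in this assay, at which 2 of the 3 values shown sit, covers two of the three values and leaves the steps open.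

Compound 4 `Nc1cc(N)c2nc(-c3ccccc3)c(Sc3ccc(Cl)c(Cl)c3)nc2c1` differs from compound 3 in one place: 3,4-dichlorophenyl in place of 4-methoxyphenyl on a sulfur. The measured steps bear on it only loosely, since none has a readable size; the change keeps the sulfur link of compound 3 and brings in the 3,4-dichlorophenyl that compound 1 carries on its oxygen. No direction beyond the scatter can be drawn from the data. Compound 4 is expected to give about 50000 nM in this assay, between 15000 nM and 100000 nM. The expected step is a step that the limit leaves unreadable from compound 3 to compound 4, with a real chance that only a limit is returned again.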

Compound 4, concentration lethal to 50% of the cells: < 100000 nM
Compound 4 was reported as a limit; the forecaster's own chance of this, stated with the estimate: 50%; the middle value lies beyond the limit too.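

No new step can be read for compound 4 against compound 1, compound 2 or compound 3, because its result in this assay is again a limit: the limit of < 100000 nM in this assay, at which 3 of the 4 values shown sit.

The compounds shown leave open whether changing the group on the shared core moves the value in this assay at all.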